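Phenyl at the chain end of compound 2

A few compounds are considered here, and "the series" means these few. Any claim that something is new, unique, unknown or untested is made for them only; others in the source may bear on it.

Measured in a functional assay on A-431 cells (Homo sapiens) for inhibition; a lower number here means a stronger inhibitor, a higher number a weaker inhibitor:
- compound 1 `CCCCCCC[C@@]1(C)O[C@@H]2OC(=O)N(C(=O)CCl)[C@@H]2CC1=O`: 78000 nM
- compound 2 `CCCCCC#C[C@@]1(C)O[C@@H]2OC(=O)N(C(=O)CCl)[C@@H]2CC1=O`: 47000 nM
- compound 3 `CCCCCC#C[C@]1(C)O[C@@H]2OC(=O)N(C(=O)CCl)[C@@H]2CC1=O`: 5000 nM

Compound 2 stands within the scatter of compound 1 and clearly higher than compound 3. Compound 4 `C[C@]1(C#CCCCCc2ccccc2)O[C@@H]2OC(=O)N(C(=O)CCl)[C@@H]2CC1=O`, not yet measured, changes the chain of compound 2: phenyl in place of methyl on a saturated chain carbon, four bonds along the chain from a triple-bonded carbon. The larger 9.4-fold lower number from compound 2 to compound 3 (0.97 log units; beyond the scatter) rests on (the fact that compounds 2 and 3 differ only in the configuration as drawn). Compound 4 keeps the configuration of compound 2, so that step does not apply here. With only a 1.7-fold lower number from compound 1 to compound 2 (0.22 log units; within the scatter) as a guide, no step beyond the scatter is expected in this assay. Going by the values given here, no measured compound carries a phenyl, so the range stays wide. The expected step is a 1.3-fold lower number from compound 2 to compound 4 (0.13 log units; within the scatter). For compound 4 the estimated value is 35000 nM, with an expected range from 12000 nM to 100000 nM.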

Compound 4, half-maximal inhibitory concentration: 56000 nM
Compound 4: the middle estimate sits 1.6-fold (0.20 log units) below what was measured; low and high end bracket the measured number.
By their numbers in this assay, from the lowest: compound 3; then compounds 2, 4 and 1 (each within the scatter of the next).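

In this assay, a phenyl on a saturated chain carbon, four bonds along the chain from a triple-bonded carbon, takes the place of methyl with only a 1.2-fold higher number from compound 2 to compound 4 (0.08 log units; within the scatter), so this much larger group leaves the number within the scatter. The only step beyond the scatter among these compounds remains the one in configuration, a 9.4-fold lower number from compound 2 to compound 3 (0.97 log units; beyond the scatter). Nothing available explains why the phenyl changes so little. Going by these compounds, it remains open whether phenyl would give a similar result with the configuration of compound 3. Also open, on these data alone, is how an amine or a carboxylic acid would fare at this place on the chain.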